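A few compounds are considered here, and "the series" means these few. Any claim that something is new, unique, unknown or untested is made for them only; others in the source may bear on it.

Measured compounds:
compound 1 `CC1=CC[C@H]2[C@H](CC[C@]2(C)O)C(C)(C)[C@@H]1CC[C@H]1[C@]2(C)CC[C@H](OC(=O)CCC(=O)O)C(C)(C)O[C@H]2CC[C@@]1(C)O`: 27900 nM
compound 2 `CC1=CC[C@H]2[C@@H]1CC=C(C)[C@@H](CC[C@H]1[C@]3(C)CC[C@H](OC(=O)CCC(=O)O)C(C)(C)O[C@H]3CC[C@@]1(C)O)C2(C)C`: 29600 nM
compound 3 `CC1=CC[C@H]2[C@H](CC[C@]2(C)O)C(C)(C)[C@@H]1CC[C@H]1[C@]2(C)CC[C@H](OC(=O)c3ccc(F)cc3)C(C)(C)O[C@H]2CC[C@@]1(C)O`: 11300 nM

In a functional assay on MDA-MB-231 cells (Homo sapiens) for antiproliferative activity, read by MTT assay, with a stated time of 72 h (on this read-out lower numbers stand for stronger inhibition and higher numbers for weaker inhibition), compound 3 stands lowest of the three numbers; compound 1 is its nearest neighbour and compound 2 the furthest, both beyond the scatter. Compound 4 `CC1=CC[C@H]2[C@H](CC[C@]2(C)O)C(C)(C)[C@@H]1CC[C@H]1[C@]2(C)CC[C@H](OC(=O)c3ccccc3F)C(C)(C)O[C@H]2CC[C@@]1(C)O` differs from compound 3 in one place: 2-fluorophenyl in place of 4-fluorophenyl on a carbonyl carbon. Among the measured compounds shown here, the only measured step, a 2.5-fold lower number from compound 1 to compound 3 (0.39 log units; beyond the scatter), exchanged the whole group on the carbonyl carbon and so bears only loosely on this change; no measured step moves a fluorine from one position of the phenyl ring to another. Without such a precedent, the step is expected to stay within the scatter. Compound 4 is therefore estimated at 12000 nM, between 5000 nM and 30000 nM. This estimate means an expected step of a 1.1-fold higher number from compound 3 to compound 4 (0.03 log units; within the scatter).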

Compound 4, half-maximal inhibitory concentration: 28700 nM
Estimate against measurement, compound 4: 2.4-fold (0.38 log units) below; low and high end bracket the measured number.
By their numbers in this assay, from the lowest: compound 3; then compounds 1, 4 and 2 (each within the scatter of the next).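

In this assay, 2-fluorophenyl in place of 4-fluorophenyl on the carbonyl carbon gives a 2.5-fold higher number from compound 3 to compound 4 (0.40 log units; beyond the scatter), so the same atoms joined differently do not read the same here. The lower number seen with 4-fluorophenyl is thus not shared by 2-fluorophenyl, as the comparison with 2-carboxyethyl gives a 1.0-fold higher number from compound 1 to compound 4 (0.01 log units; within the scatter). Nothing given here explains this difference. The compounds shown leave open how plain phenyl, or a phenyl ring carrying chlorine or an amine, would read on this carbonyl carbon. They also leave open whether the two fluorophenyl groups differ in the same way on the core of compound 2.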